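Two limits and an untested benzyl analogue

A few compounds are considered here, and "the series" means these few. Any claim that something is new, unique, unknown or untested is made for them only; others in the source may bear on it.

Measured so far in an assay on isolated protein for inhibition of Dipeptidyl peptidase 9 (Homo sapiens); a lower number here means a stronger inhibitor, a higher number a weaker inhibitor:
compound 1, `Cc1ccnc(Nc2cc(N3CCC[C@@H](N)C3)nc3ccnn23)c1`, gives > 100000 nM, a limit of this assay.
compound 2, `Cc1ccc(Nc2cc(N3CCC[C@@H](N)C3)nc3ccnn23)c(N)c1`, gives > 100000 nM, also a limit.

Compound 2 therefore stands at the limit of > 100000 nM in this assay, at which 2 of the 2 values shown sit; the step that the two limits leave unreadable from compound 1 to compound 2 cannot be sized. Compound 3, `N[C@@H]1CCCN(c2cc(NCc3ccc(O)cc3)n3nccc3n2)C1`, carries 4-hydroxybenzyl in place of 2-amino-4-methylphenyl on a nitrogen on an aromatic ring. No readable step bears on this change, so no direction can be drawn from the measured pair, and the step that the limit leaves unreadable from compound 2 to compound 3 is an expectation resting on that silence. Compound 3 is estimated at 150000 nM, between 30000 nM and 1000000 nM.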

Compound 3, half-maximal inhibitory concentration: > 50000 nM
Compound 3: only a limit was reported; the forecaster's own chance of this, stated with the estimate: 75%; the middle value is on the limit's open side.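

Among these compounds, compound 1, compound 2 and compound 3 all give only limits, so no step among them can be read. As far as these compounds go, how strongly each inhibits, and whether changing the group on the nitrogen matters, stays open.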